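This account rests on a few compounds, and the source may have more. Where it says the series, first, only, none or still open, it means among the compounds named here.

Measured so far in a functional assay on KB cells (Homo sapiens) for cytotoxicity; a higher number here means that more compound is needed for the effect, a lower number that less compound is needed:
Compound 1 `C=C1C(=O)O[C@@H]2C/C(C)=C/CC/C(C)=C/CC[C@]3(C)O[C@H]3C[C@@H]12` gives 9.15 ug/mL.
Compound 2 `C=C1C(=O)O[C@@H]2[C@H]1[C@H](OC(C)=O)C/C(C)=C/C[C@H](OC(C)=O)/C(C)=C/C[C@@H](OC(C)=O)[C@]1(C)O[C@@H]21` gives 8.35 ug/mL.

In this assay compound 1 has the higher of the two numbers, but the gap to compound 2 is within the usual scatter, so the two compounds cannot be separated on these values. Compound 3 `C=C1C(=O)O[C@H]2[C@H]1C[C@@H]1O[C@@]1(C)CC/C=C(\C)CC/C=C(\C)[C@@H]2OC(C)=O` has not yet been measured. It differs from compound 1 in one place: acetoxy in place of hydrogen on a saturated ring carbon. Among the measured compounds shown here, no pair of measured compounds that differ in a single place is available, so the size of this step cannot be read from a neighbouring case. The account notes that compound 2, which carries several acetoxy groups on the shared core, sits within the scatter of compound 1, so no step beyond the scatter is expected in this assay for compound 3. The expected step from compound 1 to compound 3 is a 1.1-fold lower number from compound 1 to compound 3 (0.03 log units; within the scatter). The estimate for compound 3 is 8.5 ug/mL, with a range from 3 ug/mL to 24 ug/mL.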

Compound 3, concentration for half-maximal effect: 7.39 ug/mL
Compound 3: the middle estimate sits 1.2-fold (0.06 log units) above what was measured; the range from low to high includes it.
By their numbers in this assay, from the lowest: compounds 3, 2 and 1 (each within the scatter of the next).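

In this assay, among the compounds shown here, the acetoxy in place of hydrogen on this saturated ring carbon of the 14-membered ring gives the first step that can be read for a single place: a 1.2-fold lower number from compound 1 to compound 3 (0.09 log units; within the scatter) and so compound 3 cannot be told apart from compound 1. At this position, next to the ring atom that bears a methyl group, the added acetoxy therefore leaves no mark beyond the scatter on the cytotoxicity read-out. No measured information is available to explain this result.

On these data alone, whether a free hydroxyl, an amine or a longer ester chain on the same ring carbon would also stay within the scatter remains open. So does whether a single acetoxy on another ring carbon of the shared core would behave in the same way.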